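Indolyl in Place of Phenylethenyl on Two Related Cores

A few compounds are considered here, and "the series" means these few. Any claim that something is new, unique, unknown or untested is made for them only; others in the source may bear on it.

Measured compounds:
compound 1 `CC(=O)Oc1ccc2cc(-n3cc(/C=C/c4ccccc4)nn3)c(=O)oc2c1C` gives 28500 nM;
compound 2 `CO[C@@H]1[C@@H](O)[C@@H](O)[C@H](Oc2ccc3c(c2C)OC(=O)C(n2cc(/C=C/c4ccccc4)nn2)C3)OC1(C)C` gives 14600 nM;
compound 3 `CC(=O)Oc1ccc2cc(-n3cc(-c4c[nH]c5ccccc45)nn3)c(=O)oc2c1C` gives 7450 nM.

All three numbers come from a functional assay on MCF7 cells (Homo sapiens) for antiproliferative activity; a lower number here means a stronger inhibitor, a higher number a weaker inhibitor. Between compound 1 and compound 3 one group is swapped: 1H-indol-3-yl in place of 2-phenylethenyl on an aromatic carbon. This single change produced a 3.8-fold lower number from compound 1 to compound 3 (0.58 log units; beyond the scatter). Compound 2 carries a different core; how its core differs from that of compound 1 is not broken down here, and its number lies within the usual scatter of both compound 1 and compound 3.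

Compound 4 `CO[C@@H]1[C@@H](O)[C@@H](O)[C@H](Oc2ccc3c(c2C)OC(=O)C(n2cc(-c4c[nH]c5ccccc45)nn2)C3)OC1(C)C` is compound 2 with the same swap: 1H-indol-3-yl in place of 2-phenylethenyl on an aromatic carbon. The change is the same, and the surroundings of the place are the same in words. A step of similar size is expected, resting on compound 1 and compound 3 because a 3.8-fold lower number from compound 1 to compound 3 (0.58 log units; beyond the scatter), though the different core widens the range. The expected step is a 3.7-fold lower number from compound 2 to compound 4 (0.56 log units; beyond the scatter). Compound 4 is estimated at 4000 nM, between 1200 nM and 14000 nM.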

Compound 4, half-maximal inhibitory concentration: 18300 nM
Estimate against measurement, compound 4: 4.6-fold (0.66 log units) below; measured number above the stated range.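

In this assay, placing 1H-indol-3-yl where 2-phenylethenyl stood on the core of compound 2 gives a 1.3-fold higher number from compound 2 to compound 4 (0.10 log units; within the scatter), so on this core the two groups cannot be told apart. The clear drop seen on the core of compound 1 therefore did not carry over, and the two steps truly differ: the same change on two cores in this assay, a 3.8-fold lower number (0.58 log units; beyond the scatter) from compound 1 to compound 3 and a 1.3-fold higher number (0.10 log units; within the scatter) from compound 2 to compound 4, 4.8-fold (0.68 log units) apart, beyond the scatter of two such steps. This shows that the result of the swap on one core cannot be assumed for the other, but it does not show what in the cores causes the difference or how the swap would behave on a third core.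

The compounds shown leave open how a plain phenyl group, or a group carrying an amine, would behave in the same place on each core.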